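A few compounds are considered here, and "the series" means these few. Any claim that something is new, unique, unknown or untested is made for them only; others in the source may bear on it.

Compound 1 `Cc1ccc(CS(=O)(=O)/C(=C/c2ccc(Br)cc2)C(=O)c2ccc(Cl)cc2)cc1`: 25000 nM
Compound 2 `CCOc1ccc(/C=C(\C(=O)c2ccc(Cl)cc2)S(=O)(=O)Cc2ccc(F)cc2)cc1OC`: 50000 nM

Both compounds were tested in a functional assay on DU-145 cells (Homo sapiens) for inhibition, read by trypan blue exclusion, with a stated time of 96 h (on this read-out lower numbers stand for stronger inhibition of growth and higher numbers for weaker inhibition of growth), and both sit at the weak end of what a growth test of this kind can show. Compound 2 gives 50000 nM, which lies within the usual scatter of compound 1 at 25000 nM. The two therefore cannot be ranked against each other.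

The next compound, compound 3 `O=C(/C(=C\c1ccc(Br)cc1)S(=O)(=O)Cc1ccc(F)cc1)c1ccc(Cl)cc1`, has not been measured yet. It keeps the rest of compound 2 and changes one group: 4-bromophenyl in place of 4-ethoxy-3-methoxyphenyl on a double-bonded chain carbon bound to a double-bonded chain carbon. Within the data shown here, no measured pair differs at a single place, so the effect of this swap has no direct precedent here. Among the measured compounds shown here, the only guide is compound 1, which also carries the 4-bromophenyl and gives 25000 nM. On that basis, no change beyond the scatter is expected in this assay, with a slight lean towards a lower number. The estimated change is a 1.7-fold lower number from compound 2 to compound 3 (0.22 log units; within the scatter). For compound 3 the expected value is 30000 nM, with an estimated range from 10000 nM to 70000 nM.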

Compound 3, concentration for 50% growth inhibition: > 100000 nM
Compound 3: a limit, no number; the forecaster's own chance of this, stated with the estimate: 10%; at least 3.3-fold (0.52 log units) between middle value and limit.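

In this assay compound 3 is recorded as a limit of the assay and not as a number: the limit of > 100000 nM in this assay, at which 1 of the 3 values shown sits.

Putting 4-bromophenyl in place of 4-ethoxy-3-methoxyphenyl on a double-bonded chain carbon bound to a double-bonded chain carbon gives an at least 2.0-fold higher number from compound 2 to compound 3 (0.30 log units; that floor lies within the scatter), so this swap alone is not shown to weaken growth inhibition, and it shows no sign of strengthening it either. Among these compounds, the clearer signal comes from the other single change, fluoro in place of methyl on an aromatic carbon, which gives an at least 4.0-fold higher number from compound 1 to compound 3 (0.60 log units; beyond the scatter); this is the first step to pass the scatter, and it places the visible loss of growth inhibition at the methyl and fluoro site, not at the site of the 4-bromophenyl.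

As far as these compounds go, both steps are floors, so their true sizes stay open. Also open, from the compounds shown here alone, is what an amine or a nitrile would do at the site of the methyl and fluoro, and whether methyl in place of fluoro would have the same effect alongside the 4-ethoxy-3-methoxyphenyl.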